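The compounds below may be only part of what the source reports. "The series", "measured", "known", "first", "only" and "open" are said of these compounds alone.

Three compounds built on one shared core were tested in an assay on a cell-free system (plasma) for antagonist activity at proteinase-activated receptor 4 (Homo sapiens), with a stated time of 5 min, in the presence of a further agent that is not named here; on this read-out lower numbers stand for stronger inhibition and higher numbers for weaker inhibition. Compound 1 `COc1nn2cc(-c3cc4ccccc4o3)nc2s1` is the plainest of them, and in this assay compound 1 gives 15000 nM. Compound 2 `COc1cc(OCc2ccccc2OCc2ccccc2)c2cc(-c3cn4nc(OC)sc4n3)oc2c1` carries a more elaborate side on the core, and in this assay compound 2 gives 2500 nM. Compound 3 `COc1cc(OCc2cccc(CCc3ccccc3)c2)c2cc(-c3cn4nc(OC)sc4n3)oc2c1` carries a phenethyl group on its outer ring, and in this assay compound 3 gives 1200 nM. Compound 3 therefore shows the lowest number of the three, and its gaps to compound 2 and to compound 1 both lie beyond the usual scatter, so it stands as the most potent of the set.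

Compound 4 `COc1cc(OCc2cccc(C#N)c2)c2cc(-c3cn4nc(OC)sc4n3)oc2c1` differs from compound 3 in a single place: cyano in place of phenethyl on an aromatic carbon. Among the measured compounds shown here, no measured pair shows this exact change, so the expectation rests on the wider picture: across compounds 1, 2 and 3 the more decorated members give the lower numbers, and here a group of 8 heavy atoms is traded for one of 2. A step upward, beyond the scatter, is therefore expected for compound 4, of about a 3.3-fold higher number from compound 3 to compound 4 (0.52 log units; beyond the scatter). Compound 4 is estimated at 4000 nM, within a range from 1500 nM to 12000 nM.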

Compound 4, half-maximal inhibitory concentration: 820 nM
Compound 4: middle estimate off by 4.9-fold (0.69 log units), on the high side; measured number below the stated range.
By their numbers in this assay, from the lowest: compounds 4 and 3 (each within the scatter of the next); then compound 2; then compound 1.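

In this assay, putting cyano in place of phenethyl on this aromatic carbon gives a 1.5-fold lower number from compound 3 to compound 4 (0.17 log units; within the scatter), so the two compounds cannot be told apart on this read-out. This pair, the first in the set that differs in one place, shows that the whole phenethyl group, with its 8 heavy atoms and its six-membered aromatic ring, can give way to cyano, with only 2 heavy atoms and a hydrogen-bond acceptor, without a change beyond the scatter; at this position, group size alone therefore does not set the number. Nothing available explains why two such different groups read alike here.

The compounds shown leave open how far this tolerance extends, since a carboxylic acid, an amine or a plain methoxy group at this position could give quite different numbers from those of a cyano or a phenethyl group. They also leave open whether cyano would read the same on another carbon of this ring, and whether a longer chain ending in cyano would match either compound.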